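The source may report more compounds than this note shows. Statements on the series, on what has been measured and on what is new or still open speak of the compounds shown alone.

Compound 1 `COc1ccc(C(O)C2OC(=O)c3c(OC)cc(OC)cc32)cc1`: > 40000 nM
Compound 2 `COc1cc(OC)c2c(c1)C(C(O)c1ccc(OCc3ccc(F)cc3)cc1)OC2=O`: > 40000 nM

Both entries come from an ADME assay on RAW264.7 cells (Mus musculus) for cytotoxicity, read by MTT assay, with a stated time of 24 h, in the presence of a further agent that is not named here (on this read-out higher numbers stand for weaker inhibition and lower numbers for stronger inhibition), and both are limits of the assay rather than numbers. Compound 2 stands at > 40000 nM, which is a limit. Within the data shown here, the one measured step is a step that the two limits leave unreadable from compound 1 to compound 2. What the data offer is therefore (the limit of > 40000 nM in this assay, at which 2 of the 2 values shown sit).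

Compound 3 `COc1cc(OC)c2c(c1)C(C(O)c1ccc(OCc3ccc(Br)cc3)cc1)OC2=O` changes compound 2 in a single place: bromo in place of fluoro on an aromatic carbon. The bromo group of compound 3 sits para to a large group. Among the measured compounds shown here, no measured step covers this exchange, so its size cannot be read from the data. No step beyond the scatter is expected in this assay, and no direction can be assigned. The expected step is a step that the limit leaves unreadable from compound 2 to compound 3. Compound 3 is estimated at 50000 nM, with an expected range of 25000 nM to 100000 nM.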

Compound 3, half-maximal inhibitory concentration: > 40000 nM
Compound 3: a limit, no number; the forecaster's own chance of this, stated with the estimate: 85%; the middle value does not contradict the limit.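

No step between compound 1, compound 2 and compound 3 can be read, as all three values are limits and not numbers: the limit of > 40000 nM in this assay, at which 3 of the 3 values shown sit.

The compounds shown leave open in this assay whether bromo in place of fluoro changes the cytotoxicity at all.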